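The source may hold more compounds than are shown below. What is called first, only, known or untested is meant among the compounds shown, and "the series" means these compounds.

Measured so far in an assay on HEK293 cells for negative allosteric modulation of metabotropic glutamate receptor 5 (Homo sapiens), read by FLIPR; on this read-out lower numbers stand for stronger inhibition and higher numbers for weaker inhibition:
compound 1 `O=C(C1CCC2(CCC2)CC1)N1CC(c2nc(-c3cccc(Cl)c3)no2)C1` gives > 10000 nM, a limit of the assay and not a number.
compound 2 `Cc1cccc(-c2noc(C3CN(C(=O)c4ccccc4F)C3)n2)c1` gives 1400 nM.
compound 3 `O=C(C1CCC(C(F)(F)F)CC1)N1CC(c2nc(-c3cccc(F)c3)no2)C1` gives > 10000 nM, again a limit of the assay.

Compound 1 stands at the limit of > 10000 nM in this assay, at which 2 of the 3 values shown sit; it is one of the two values at the limit, and only compound 2, which carries an aromatic ring on the carbonyl carbon, gives a number in this assay. Compound 1 and compound 3 both carry a saturated carbocycle there. For the measured compounds named here, no pair of measured compounds differing in one place is available, so the change from compound 1 to compound 4 `COC1CCCN(C(=O)N2CC(c3nc(-c4cccc(Cl)c4)no3)C2)C1` has no measured counterpart: a group of 8 heavy atoms (6 carbon, 1 nitrogen, 1 oxygen; one six-membered non-aromatic ring with 1 hetero atom) in place of a group of 9 heavy atoms (9 carbon; one four-membered non-aromatic ring of carbon only, one six-membered non-aromatic ring of carbon only), on a carbonyl carbon. The entering group is a saturated ring with a hetero atom and one hydrogen-bond acceptor, and nothing measured tells how such a group behaves on this carbonyl carbon. Because compound 1 sits at the limit of > 10000 nM in this assay, at which 2 of the 3 values shown sit, the step can only register as a move into the measurable range or as no change at all. With two of three values at the limit, the expectation for compound 4 is weak activity, most likely at or near the limit. Compound 4 is estimated at 9000 nM, with a range from 2500 nM to 30000 nM, and the expected step of an at least 1.1-fold lower number from compound 1 to compound 4 (0.04 log units; that floor lies within the scatter) is not beyond the scatter.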

Compound 4, half-maximal inhibitory concentration: 1830 nM
Estimate against measurement, compound 4: 4.9-fold (0.69 log units) above; measured number below the stated range.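

In this assay, the carbonyl carbon of the shared core can carry a saturated ring with a hetero atom and still give a measurable number: exchanging the carbon-only group of compound 1 for 3-methoxypiperidin-1-yl gives an at least 5.4-fold lower number from compound 1 to compound 4 (0.73 log units; beyond the scatter). For the compounds shown here, this is the first read on a non-aromatic group at this place that leaves the limit, and the only single-place change available so far. Compound 1 is a limit and not a number, so the step is a floor and not a size, because its starting point is: the limit of > 10000 nM in this assay, at which 2 of the 4 values shown sit.

The change replaces the whole group, so the compounds shown do not separate the part played by the methoxy group from that of the piperidine ring joined through its nitrogen, and whether the position of the methoxy group on the ring matters also stays open. Unsubstituted piperidin-1-yl, morpholin-4-yl or 4-methoxypiperidin-1-yl on the same carbonyl carbon, with the rest of compound 4 kept, would each address one of these points.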